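The source may report more compounds than this note shows. Statements on the series, on what has been measured and on what is new or still open speak of the compounds shown alone.

Two measured compounds set the scene. In an assay on isolated protein (Prunus dulcis) for binding affinity to Beta-glucosidase (Prunus avium) (a lower number here means a stronger inhibitor, a higher number a weaker inhibitor), compound 1 `O[C@H]1[C@H](O)COC[C@@H]1O` gives 39000000 nM, while compound 2 `OC[C@H]1OC[C@@H](O)[C@H]1O` gives 14800000 nM, the lower of the two numbers, with compound 1 standing higher by more than the usual scatter. Compound 3 `OC[C@H]1OC[C@@H](O)[C@@H]1O` differs from compound 2 only in this respect: the two compounds have the same atoms and bonds and differ only in configuration as drawn: 1 of 3 stereo elements differ; a stereocentre at a saturated ring carbon is drawn R in compound 2 and S in compound 3. Among the measured compounds shown here, no measured pair shows what such a change does here, so for the step from compound 2 to compound 3 the expected change is a 1.4-fold higher number from compound 2 to compound 3 (0.13 log units; within the scatter), not clearly beyond the scatter. Compound 3 is therefore estimated at 20000000 nM, with a range from 5000000 nM to 80000000 nM.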

Compound 3, inhibition constant: 36200000 nM
Beside the measured number, compound 3's estimate is 1.8-fold (0.26 log units) below it; the measured number falls inside the stated range.
By their numbers in this assay, from the lowest: compound 2; then compounds 3 and 1 (each within the scatter of the next).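

In this assay, among the compounds shown here, inverting a single stereocentre at a saturated ring carbon from R to S gives a 2.4-fold higher number from compound 2 to compound 3 (0.39 log units; beyond the scatter), the first step that can be read. Though modest, it shows that configuration at this one position is enough to move the number beyond the scatter, with nothing entering or leaving. The step can be traced to that one change alone: the fact that compounds 2 and 3 differ only in the configuration as drawn

Going by these compounds, whether the other two stereocentres matter to a similar degree remains open. So does what an amine on the shared core would do to the number.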